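Swapping the Aryl Group: Expected Tolerance of Compound 4

A few compounds are considered here, and "the series" means these few. Any claim that something is new, unique, unknown or untested is made for them only; others in the source may bear on it.

Compound 1 `COc1nc(-c2ccccc2F)ccc1[C@@H](c1ccccc1)[C@@](O)(CCN(C)C)c1cccc2ccccc12`: "nd" (no result reported)
Compound 2 `COc1ccc(-c2ccc([C@@H](c3ccccc3)[C@@](O)(CCN(C)C)c3cccc4ccccc34)c(OC)n2)cc1`: > 64 ug/mL
Compound 3 `COc1nc(-c2cccc(F)c2)ccc1[C@@H](c1ccccc1)[C@@](O)(CCN(C)C)c1cccc2ccccc12`: 62.8 ug/mL

Among the measured compounds shown here, in a toxicity assay on HeLa cells (Homo sapiens) for cytotoxicity (a higher number here means that more compound is tolerated, a lower number that less compound is tolerated), compound 3 gives 62.8 ug/mL, the only single number among the three. For compound 2 the assay reports only a limit, > 64 ug/mL, as noted in the limit of > 64 ug/mL in this assay, at which 1 of the 3 values shown sits. Compound 1 has no result. Compound 4 `COc1nc(-c2ccc(Cl)cc2)ccc1[C@@H](c1ccccc1)[C@@](O)(CCN(C)C)c1cccc2ccccc12` differs from compound 3 by 4-chlorophenyl in place of 3-fluorophenyl on an aromatic carbon. For the measured compounds named here, one measured step bears on this change: an at least 1.0-fold lower number from compound 2 to compound 3 (0.00 log units; that floor lies within the scatter) exchanged the same aryl group and stayed within the scatter. A step of similar size is therefore expected here, with no direction beyond the scatter. Compound 4 is expected to give 58 ug/mL, with a range from 30 ug/mL to 64 ug/mL, so that a 1.1-fold lower number from compound 3 to compound 4 (0.03 log units; within the scatter) is expected to fall within the scatter.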

Compound 4, half-maximal cytotoxic concentration: > 64 ug/mL
Compound 4: no number, only a limit; the forecaster's own chance of this, stated with the estimate: 40%; at least 1.1-fold (0.04 log units) between middle value and limit.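

In this assay, 4-chlorophenyl in place of 3-fluorophenyl at this position gives an at least 1.0-fold higher number from compound 3 to compound 4 (0.00 log units; that floor lies within the scatter), so this swap shows no readable loss of tolerance. The step between compound 2 and compound 4 cannot be read, as both values are limits. With compound 4, a second aryl group at this position reaches the top of the readable range: the limit of > 64 ug/mL in this assay, at which 2 of the 4 values shown sit.

From the compounds shown here alone, how far tolerance extends past that limit for compound 2 and compound 4 stays open. Going by these compounds, it is also open whether an amine or a carboxylic acid on this aryl ring would lower the number beyond the scatter.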